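The source may hold more compounds than are shown below. What is called first, only, known or untested is meant among the compounds shown, and "the series" means these compounds.

In an assay on isolated protein for inhibition of Maltase-glucoamylase (Homo sapiens), tested at 100 uM (on this read-out lower numbers stand for less inhibition and higher numbers for more inhibition at the one concentration tested (going by the name of the read-out)), compound 1 `CSc1c(C#N)c(N)c(C#N)c(-c2ccccc2)c1-c1ccccc1` gives 10.5%, compound 2 `CSc1c(C#N)c(N)c(C#N)c(C)c1-c1ccc(F)cc1` gives 17.3%, and compound 3 `CSc1c(C)c(-c2ccccc2)c(C#N)c(N)c1C#N` gives 6.7%. Compound 3 holds the lowest of the three numbers; its nearest neighbour is compound 1, which lies within the scatter of it, while compound 2 stands beyond the scatter. Among the compounds with values here, the only step measured between compounds that differ in one place runs a number 3.8 percentage points lower from compound 1 to compound 3 (within the scatter), a change that left the readout essentially where it was. Compound 4 `CSc1c(C)c(-c2ccc(Cl)cc2)c(C#N)c(N)c1C#N` differs from compound 3 by chloro in place of hydrogen on an aromatic carbon. Within the data shown here, no measured step matches this change: the step from compound 1 to compound 3 swaps out a whole phenyl and says nothing about a chloro on that ring, and compound 2, whose aryl ring carries a fluorine, differs from compound 1 and compound 3 in more than one place, so its value alone cannot be read as a step. With nothing pointing either way, compound 4 is expected to sit close to its parent, with an expected step of a number 3.3 percentage points higher from compound 3 to compound 4 (within the scatter) and an estimated value of 10%, between 0% and 25%.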

Compound 4, a percentage reported as inhibition, at one concentration (the size of the read-out at that concentration, not a potency): 6.7%
Compound 4: the middle estimate sits 3.3 percentage points above what was measured; the measured number falls inside the stated range.
By their numbers in this assay, from the lowest: compounds 3, 4, 1 and 2 (each within the scatter of the next, the first and the last beyond it).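

Going from phenyl to 4-chlorophenyl gives no change at the digits printed from compound 3 to compound 4 (within the scatter) in this assay, so chloro in place of hydrogen at this place, para to a large group, leaves the read-out where it stood. Within the data shown here, the earlier step had only replaced a whole phenyl with methyl, whereas this pair is the first to show a change on the phenyl ring itself, and with this one pair the finding holds only for chloro on the core of compound 3 at the single concentration tested. No available evidence bears on this result.

Going by these compounds, it remains open whether an amine or a carboxylic acid at the same place would shift the read-out. The compounds shown also leave open whether a methoxy group or a longer chain there would do so, and whether chloro would give the same step on the core of compound 1.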